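A few compounds are considered here, and "the series" means these few. Any claim that something is new, unique, unknown or untested is made for them only; others in the source may bear on it.

Compound 1 `C/C(=C\CC/C(C)=C/CC[C@@H]1[C@@]2(C)CCC(=O)C(C)(C)[C@H]2CC[C@@]1(C)O)CC/C=C(\C)C(=O)OCc1cn(-c2ccccc2)nn1`: in a functional assay on A549 cells (Homo sapiens) for antiproliferative activity, read by MTT assay, with a stated time of 48 h (on this read-out lower numbers stand for stronger inhibition and higher numbers for weaker inhibition), compound 1 gives > 150000 nM, which is a limit of the assay and not a number.
Compound 2 `C/C(=C\CC/C(C)=C/CC[C@@H]1[C@@]2(C)CCC(=O)C(C)(C)[C@H]2CC[C@@]1(C)O)CC/C=C(\C)C(=O)OCc1cn(-c2ccc(Br)cc2)nn1`: in this assay compound 2 gives > 150000 nM, again a limit rather than a number.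
Compound 3 `C/C(=C\CC/C(C)=C/CC[C@@H]1[C@@]2(C)CCC(=O)C(C)(C)[C@H]2CC[C@@]1(C)O)CC/C=C(\C)C(=O)OCc1cn(-c2ccccc2F)nn1`: in this assay compound 3 gives > 150000 nM, also only a limit.

Compound 3 therefore stands where the other two stand, at the limit of > 150000 nM in this assay, at which 3 of the 3 values shown sit. The steps a step that the two limits leave unreadable from compound 1 to compound 2, a step that the two limits leave unreadable from compound 1 to compound 3 and a step that the two limits leave unreadable from compound 2 to compound 3 cannot be sized, since each end is a limit. Compound 4 `C/C(=C\CC/C(C)=C/CC[C@@H]1[C@@]2(C)CCC(=O)C(C)(C)[C@H]2CC[C@@]1(C)O)CC/C=C(\C)C(=O)OCc1cn(-c2cccc(C)c2)nn1` differs from compound 3 by 3-methylphenyl in place of 2-fluorophenyl on an aromatic nitrogen. The step from compound 2 to compound 3, which also swaps the ring on that aromatic nitrogen, is the one that bears on this change, yet it gives no size or direction. With all three values at the limit, no step beyond the scatter is expected; the estimated step is a step that the limit leaves unreadable from compound 3 to compound 4. Compound 4 is thus expected to give about 200000 nM, somewhere between 100000 nM and 600000 nM, most likely reported again only as a limit.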

Compound 4, half-maximal inhibitory concentration: > 150000 nM
Compound 4 gave a limit, no number (the forecaster's own chance of this, stated with the estimate: 85%); the middle value does not contradict the limit.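

Compound 4, like compounds 1, 2 and 3, gives only a limit, and no step among these four compounds can be read. As far as these compounds go, whether changing the group on the aromatic nitrogen alters activity in this assay stays open.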